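The source may hold more compounds than are shown below. What is called first, only, known or untested is meant among the compounds shown, and "the series" means these compounds.

Measured compounds:
compound 1 `O=C(Nc1cccc(-c2oc3cc(-c4ccc(F)cc4)ccc3c(=O)c2O)c1)c1ccc(F)cc1`, 14200 nM
compound 2 `COc1ccc(C(=O)Nc2cccc(-c3oc4cc(-c5ccc(F)cc5)ccc4c(=O)c3O)c2)cc1`, 5490 nM
compound 3 `O=C(Nc1cccc(-c2oc3cc(-c4ccc(F)cc4)ccc3c(=O)c2O)c1)c1ccc(Br)cc1`, 8630 nM

In a functional assay on HCC1937 cells (Homo sapiens) for antiproliferative activity, read by CCK-8 assay, with a stated time of 72 h (on this read-out lower numbers stand for stronger inhibition and higher numbers for weaker inhibition), compound 1 stands highest of the three numbers; compound 3 is nearest to it, compound 2 furthest. The step from compound 1 to compound 2 read a 2.6-fold lower number from compound 1 to compound 2 (0.41 log units; beyond the scatter), while the step from compound 1 to compound 3 read a 1.6-fold lower number from compound 1 to compound 3 (0.22 log units; within the scatter). Compound 4 `COc1ccc(C(=O)Nc2cccc(-c3oc4cc(-c5ccc(F)cc5)ccc4c(=O)c3O)c2)c(F)c1` is not yet measured. It differs from compound 1 by 2-fluoro-4-methoxyphenyl in place of 4-fluorophenyl on a carbonyl carbon. The change shares the methoxy in place of fluoro that the step from compound 1 to compound 2 tested, and that step is the one that bears on it; the added fluoro has no measured counterpart among these compounds. A modest step downward is therefore expected, a 2.6-fold lower number from compound 1 to compound 4 (0.41 log units; beyond the scatter). For compound 4 the estimated value is 5500 nM, within the range 2500 nM to 12000 nM.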

Compound 4, half-maximal inhibitory concentration: 24500 nM
Estimate against measurement, compound 4: 4.5-fold (0.65 log units) below; the measured number lies above the stated range.
By their numbers in this assay, from the lowest: compounds 2, 3, 1 and 4 (each within the scatter of the next, the first and the last beyond it).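

In this assay, fluoro in place of hydrogen on an aromatic carbon gives a 4.5-fold higher number from compound 2 to compound 4 (0.65 log units; beyond the scatter), so the lower number seen with methoxy does not carry over once this fluoro is present. Against the 4-fluorophenyl group, the 2-fluoro-4-methoxyphenyl group shows a 1.7-fold higher number from compound 1 to compound 4 (0.24 log units; within the scatter), and against the 4-bromophenyl group it shows a 2.8-fold higher number from compound 3 to compound 4 (0.45 log units; beyond the scatter). Nothing available here explains the step from the added fluoro. From the compounds shown here alone, it remains open whether fluoro elsewhere on this ring would read the same, and how an amine or a carboxylic acid there would read.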